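From compound 2 to compound 4: the carbonyl substituent

The source may report more compounds than this note shows. Statements on the series, on what has been measured and on what is new or still open speak of the compounds shown alone.

Of the compounds shown here, three have numbers so far in a functional assay on DU-145 cells (Homo sapiens) for inhibition, read by trypan blue exclusion, with a stated time of 96 h; a lower number here means a stronger inhibitor of growth, a higher number a weaker inhibitor of growth. Compound 1 (`O=C(/C(=C\c1ccc(Br)cc1)SCc1ccc(Cl)cc1)c1ccc(Br)cc1`) gives 1000 nM and compound 2 (`O=C(/C(=C\c1ccc(O)c([N+](=O)[O-])c1)SCc1ccc(Br)cc1)c1c(F)c(F)c(F)c(F)c1F`) gives 10000 nM while compound 3 (`O=C(/C(=C\c1ccc(O)c([N+](=O)[O-])c1)S(=O)(=O)Cc1ccc(Br)cc1)c1c(F)c(F)c(F)c(F)c1F`) gives 50000 nM as its number. Compound 2 therefore stands in the middle of the three. Compound 4 (`O=C(/C(=C\c1ccc(O)c([N+](=O)[O-])c1)SCc1ccc(Br)cc1)c1ccc(Cl)cc1Cl`) carries 2,4-dichlorophenyl in place of 2,3,4,5,6-pentafluorophenyl on a carbonyl carbon. Among the compounds with values here, the only measured single change, a 5.0-fold higher number from compound 2 to compound 3 (0.70 log units; beyond the scatter) and modest in size, lies at the (4-bromobenzyl)sulfanyl group, so it sets no direct size for a change on the carbonyl carbon. Compound 1 also lacks 2,3,4,5,6-pentafluorophenyl and shows 1000 nM but differs from compound 2 in other places too, which makes it weak support for a move downward. In this assay a modest move to a lower number is expected, an estimated 3.3-fold lower number from compound 2 to compound 4 (0.52 log units; beyond the scatter) for this swap. For compound 4 the estimated value is 3000 nM with an expected range (800 nM to 12000 nM).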

Compound 4, concentration for 50% growth inhibition: 10000 nM
For compound 4 the middle estimate is 3.3-fold (0.52 log units) below the measured one, and the stated range covers the measured number.
By their numbers in this assay, from the lowest: compound 1; then compounds 2 and 4 (each within the scatter of the next); then compound 3.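

In this assay the carbonyl carbon now has its first direct reading: 2,4-dichlorophenyl in place of 2,3,4,5,6-pentafluorophenyl gives no change at the digits printed from compound 2 to compound 4 (within the scatter) with the rest of the structure held fixed, so these two halogenated aryl groups cannot be told apart here. Within the data shown here, the other single change, a 5.0-fold higher number from compound 2 to compound 3 (0.70 log units; beyond the scatter) at the (4-bromobenzyl)sulfanyl group, is so far the only one that moves the number beyond the scatter. No measured property is available to account for the flat result at the carbonyl carbon.

As far as these compounds go, whether this flat reading extends to unsubstituted phenyl, a methoxyphenyl or a saturated cyclohexyl group on the carbonyl carbon remains open. Also open, from the compounds shown here alone, is whether the sulfonyl step seen with the pentafluorophenyl group recurs with 2,4-dichlorophenyl in that place.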